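The source may hold more compounds than are shown below. What is called first, only, known or untested is meant among the compounds shown, and "the series" means these compounds.

In a functional assay on MDA-MB-468 cells (Homo sapiens) for antiproliferative activity, read by WST assay, with a stated time of 3 days (on this read-out lower numbers stand for stronger inhibition and higher numbers for weaker inhibition), compound 1 `[N-]=[N+]=Nc1cc(=O)[nH]c(=O)n1[C@@H]1O[C@H](CO)[C@@H](O)[C@H]1O` gives > 50000 nM, which is a limit of the assay and not a number. Compound 2 `O=c1[nH]c(=O)n([C@@H]2O[C@H](CO)[C@@H](O)[C@H]2O)c(I)c1F` gives > 50000 nM, and this too is a limit and not a number. Compound 2 therefore has no exact value to start from, and the picture so far is the limit of > 50000 nM in this assay, at which 2 of the 2 values shown sit.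

Compound 3 `[N-]=[N+]=Nc1c(F)c(=O)[nH]c(=O)n1[C@@H]1O[C@H](CO)[C@@H](O)[C@H]1O` differs from compound 2 in one place. It has azido in place of iodo on an aromatic carbon, next to the ring nitrogen and ortho to a fluoro group (azido in place of iodo on an aromatic carbon).

Within the data shown here, no measured step shows what such a swap does in this assay, so any forecast here is uncertain. A reading at the limit again is quite possible for compound 3. If a number does appear, a modest move toward stronger inhibition is expected, and the estimated size is an at least 2.0-fold lower number from compound 2 to compound 3 (0.30 log units; that floor lies within the scatter). For compound 3 the expected value is 25000 nM, with an estimated range from 4000 nM to 60000 nM.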

Compound 3, half-maximal inhibitory concentration: 1800 nM
Estimate against measurement, compound 3: 14-fold (1.14 log units) above; the measured number lies below the stated range.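

Among these compounds, on the aromatic carbon next to the ring nitrogen and ortho to a fluoro group, putting azido in place of iodo gives an at least 27-fold lower number from compound 2 to compound 3 (1.44 log units; beyond the scatter), the first real number in this assay. The fluoro group counts as well: with azido kept in place, fluoro in place of hydrogen on an aromatic carbon gives an at least 27-fold lower number from compound 1 to compound 3 (1.44 log units; beyond the scatter). Among these compounds, therefore, neither azido without the fluoro group nor the fluoro group with iodo leaves the limit, and only the pairing of azido and fluoro in compound 3 gives a measured value, while the other compounds stay where they were: the limit of > 50000 nM in this assay, at which 2 of the 3 values shown sit.

As far as these compounds go, what remains open is whether azido itself matters at this position, or whether another group there, such as an amine or a chloro group, would serve as well when ortho to the fluoro group. From the compounds shown here alone, it is equally open whether a chloro or methyl group in place of the fluoro group would hold the activity of compound 3, which gives 1800 nM.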